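Methyl in place of dimethylamino on a sulfonyl sulfur

The compounds below may be only part of what the source reports. "The series", "measured", "known", "first", "only" and "open" are said of these compounds alone.

Measured so far in an ADME assay on a cell-free system (plasma, Rattus norvegicus); on this read-out lower numbers stand for a smaller free fraction and higher numbers for a larger free fraction:
- compound 1 `COCCN(C)S(=O)(=O)c1ccc(C)c(C#Cc2cc(Cl)ccc2OCC(=O)O)c1` gives 0.007
- compound 2 `CS(=O)(=O)c1ccc(Cl)c(C#Cc2cc(Cl)ccc2OCC(=O)O)c1` gives 0.003
- compound 3 `Cc1ccc(S(=O)(=O)N(C)C)cc1C#Cc1cc(Cl)ccc1OCC(=O)O` gives 0.004

Compound 3 lies within the scatter of both compound 1 and compound 2. Compound 4 `Cc1ccc(S(C)(=O)=O)cc1C#Cc1cc(Cl)ccc1OCC(=O)O` differs from compound 3 in one place, with methyl in place of dimethylamino on a sulfonyl sulfur as the change. The closest measured step is a 1.8-fold lower number from compound 1 to compound 3 (0.24 log units; within the scatter) for hydrogen in place of methoxymethyl on a saturated chain carbon bound to a sulfonamide nitrogen. Compound 2 also carries methylsulfonyl, though it differs elsewhere, and gives 0.003 within the scatter of compound 3. No shift beyond the scatter is therefore expected in this assay here. The expected change is a 1.3-fold higher number from compound 3 to compound 4 (0.10 log units; within the scatter) and stays within the scatter. Compound 4 is estimated at 0.005 with an expected range from 0.003 to 0.01 on this measurement.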

Compound 4, unbound fraction: 0.014
Beside the measured number, compound 4's estimate is 2.8-fold (0.45 log units) below it, outside the stated range (above it).
By their numbers in this assay, from the lowest: compounds 2, 3, 1 and 4 (each within the scatter of the next, the first and the last beyond it).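

In this assay, among the compounds shown here, methyl in place of dimethylamino on a sulfonyl sulfur gives a 3.5-fold higher number from compound 3 to compound 4 (0.54 log units; beyond the scatter), so this position can shift the free fraction beyond the scatter, which no earlier step showed. Methyl in place of chloro on an aromatic carbon gives a 4.7-fold higher number from compound 2 to compound 4 (0.67 log units; beyond the scatter), so that second place matters as well. Methyl in place of (2-methoxyethyl)(methyl)amino on the same sulfur gives a 2.0-fold higher number from compound 1 to compound 4 (0.30 log units; within the scatter), which stays within the scatter.

Going by these compounds, whether ethyl on that sulfur would behave like methyl remains open. Nothing shown here explains these shifts.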